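The source may report more compounds than this note shows. Statements on the series, on what has been measured and on what is new or still open speak of the compounds shown alone.

Measured so far:
Compound 1 `[N-]=[N+]=NCc1ncnc2c1ncn2[C@@H]1O[C@H](CO)[C@@H](O)[C@H]1O`: 1590 nM
Compound 2 `CSCc1ncnc2c1ncn2[C@@H]1O[C@H](CO)[C@@H](O)[C@H]1O`: > 30000 nM

In a functional assay on L1210 cells (Mus musculus) for inhibition, with a stated time of 72 h (on this read-out higher numbers stand for weaker inhibition and lower numbers for stronger inhibition), compound 1 gives 1590 nM. Compound 2 gives > 30000 nM, and this is a limit of the assay, not a number. Its standing is therefore known only as the limit of > 30000 nM in this assay, at which 1 of the 2 values shown sits.

The next compound, compound 3 `CN(Cc1ccccc1)Cc1ncnc2c1ncn2[C@@H]1O[C@H](CO)[C@@H](O)[C@H]1O`, carries benzyl(methyl)amino in place of methylsulfanyl on a saturated chain carbon bound to an aromatic carbon.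

For the measured compounds named here, only one measured step bears on this change: an at least 18-fold higher number from compound 1 to compound 2 (1.27 log units; beyond the scatter). That step was large and beyond the scatter, so the group at this place can matter greatly in this assay. It does not involve the entering group, however, and it gives no direction for this replacement. Going by the values given here, no measured compound carries an amino group here. The expectation is therefore that compound 3 stays weak, near the limit, with only a modest chance of a clear gain in inhibition.

The expected step is an at least 1.2-fold lower number from compound 2 to compound 3 (0.07 log units; that floor lies within the scatter). For compound 3 the estimated value is 25000 nM, with an expected range from 8000 nM to 60000 nM.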

Compound 3, half-maximal inhibitory concentration: 4800 nM
The estimate for compound 3 lay 5.2-fold (0.72 log units) above the measured number; measured number below the stated range.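

In this assay, benzyl(methyl)amino on a saturated chain carbon bound to an aromatic carbon brings back a measurable inhibition, with an at least 6.2-fold lower number from compound 2 to compound 3 (0.79 log units; beyond the scatter), which shows that the loss seen with methylsulfanyl does not extend to every replacement of azido. Compound 2 is held at a limit of the assay and not at a number, so this step gives a floor and not a size: the limit of > 30000 nM in this assay, at which 1 of the 3 values shown sits. Azido keeps the lower number, with a 3.0-fold higher number from compound 1 to compound 3 (0.48 log units; beyond the scatter), so this amine does not match azido, yet the place accepts a group carrying a six-membered aromatic ring of carbon only at a modest cost.

The compounds shown do not separate the contribution of the amine nitrogen from that of the benzyl group, a question that dimethylamino or benzylsulfanyl at this place would address. They also leave open how a hydroxyl group, a primary amine or a longer alkyl chain would compare with azido, and whether any group here could give a lower number than compound 1.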